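An Ethylphenyl Variant in a Cell-Growth Series

The compounds below may be only part of what the source reports. "The series", "measured", "known", "first", "only" and "open" are said of these compounds alone.

Compound 1 `C=CC(=O)Nc1cccc(NC(=O)CSc2nc(Nc3ccccc3Cl)c3ccccc3n2)c1` gives 20700 nM.
Compound 2 `C=CC(=O)Nc1cccc(NC(=O)CSc2nc(Nc3ccccc3Br)c3ccccc3n2)c1` gives 12800 nM.
Compound 3 `C=CC(=O)Nc1cccc(NC(=O)CSc2nc(Nc3cccc(C)c3)c3ccccc3n2)c1` gives 20900 nM.

In a functional assay on MGC-803 cells (Homo sapiens) for inhibition, read by MTT assay, with a stated time of 72 h (on this read-out lower numbers stand for stronger inhibition and higher numbers for weaker inhibition), compound 3 holds the highest of the three numbers, yet its separation from its neighbours is small: a 1.0-fold higher number from compound 1 to compound 3 (0.00 log units; within the scatter) and a 1.6-fold higher number from compound 2 to compound 3 (0.21 log units; within the scatter), both within the scatter. Compound 4 `C=CC(=O)Nc1cccc(NC(=O)CSc2nc(Nc3ccc(CC)cc3)c3ccccc3n2)c1` takes a further variation at the same position: 4-ethylphenyl in place of 3-methylphenyl on a nitrogen on an aromatic ring. The two measured swaps of the aryl group on that nitrogen, from compound 1 and compound 2 to compound 3, each stayed within the scatter, so compound 4 is expected to show no step beyond the scatter in this assay, a 1.2-fold lower number from compound 3 to compound 4 (0.06 log units; within the scatter). Compound 4 is therefore estimated at 18000 nM, with a range from 9000 nM to 40000 nM.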

Compound 4, half-maximal inhibitory concentration: 8010 nM
For compound 4 the middle estimate is 2.2-fold (0.35 log units) above the measured one, and the stated range ends above it.
By their numbers in this assay, from the lowest: compounds 4, 2, 1 and 3 (each within the scatter of the next, the first and the last beyond it).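

In this assay, a change of the aryl group on this nitrogen now gives steps beyond the scatter: a 2.6-fold lower number from compound 3 to compound 4 (0.42 log units; beyond the scatter) and a 2.6-fold lower number from compound 1 to compound 4 (0.41 log units; beyond the scatter), both modest. The 2-bromophenyl group stays level with 4-ethylphenyl, at a 1.6-fold lower number from compound 2 to compound 4 (0.20 log units; within the scatter), so 4-ethylphenyl is not set apart from every aryl group shown. Nothing measured here accounts for these steps.

The compounds shown leave open whether the step belongs to the ethyl chain itself or to where it sits on the ring, and whether a longer chain such as propyl, or an amine in its place, would extend it.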